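Chlorine moved on the benzyl arm of a rat artery series

The source may report more compounds than this note shows. Statements on the series, on what has been measured and on what is new or still open speak of the compounds shown alone.

In a functional assay on the whole organism (artery, strain albino) with Rattus norvegicus as the target, with a stated time of 120 min, at a dose of 10 mg/kg by the oral route (on this read-out lower numbers stand for less inhibition and higher numbers for more inhibition at the one dose given (going by the name of the read-out)), compound 1 `CC1=C(C(=O)Nc2ccc(Br)cc2)C(c2ccc(Cl)cc2Cl)N=C(SCc2ccccc2)N1` gives 10.3%, and compound 2 `CC1=C(C(=O)Nc2ccc(Br)cc2)C(c2ccc(Cl)cc2Cl)N=C(SCc2cccc(Cl)c2)N1` gives 8.8%. Going by the values given here, compound 2 stands lowest of the two numbers, though the single measured step, a number 1.5 percentage points lower from compound 1 to compound 2 (within the scatter), lies within the scatter. Compound 3 `CC1=C(C(=O)Nc2ccc(Br)cc2)C(c2ccc(Cl)cc2Cl)N=C(SCc2ccc(Cl)cc2)N1` differs from compound 2 by 4-chlorophenyl in place of 3-chlorophenyl on a saturated chain carbon bound to a sulfur. No measured step relocates the chlorine; the only step shown, a number 1.5 percentage points lower from compound 1 to compound 2 (within the scatter), concerns adding it and bears only loosely on this change. The expected step in this assay is therefore a number 0.2 percentage points higher from compound 2 to compound 3 (within the scatter), none beyond the scatter. Compound 3 is estimated at 9%, with a range from 0% to 20%.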

Compound 3, a percentage reported as inhibition, in the whole organism at one dose (the size of the read-out at that dose, not a potency): 17.5%
Estimate against measurement, compound 3: 8.5 percentage points below; the range from low to high includes it.
By their numbers in this assay, from the lowest: compounds 2, 1 and 3 (each within the scatter of the next).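

In this assay the change from 3-chlorobenzyl to 4-chlorobenzyl on the sulfanyl arm gives a number 8.7 percentage points higher from compound 2 to compound 3 (within the scatter) and thus does not separate the two chlorine placements. The 4-chlorophenyl group against the unsubstituted benzyl arm gives a number 7.2 percentage points higher from compound 1 to compound 3 (within the scatter) and likewise leaves the chlorine with no effect that stands clear of the scatter at this position. Nothing available bears on the reason for these numbers.

Still open, from the compounds shown here alone, is whether any replacement on this arm moves the read-out beyond the scatter. An amine or a carboxylic acid in place of the chlorine, or a longer chain in place of the benzyl carbon, would test this.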